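The source may hold more compounds than are shown below. What is called first, only, known or untested is meant among the compounds shown, and "the series" means these compounds.

Measured in a functional assay on KB cells (Homo sapiens) for cytotoxicity, read by sulforhodamine B assay; on this read-out lower numbers stand for stronger inhibition and higher numbers for weaker inhibition:
- compound 1 `C=C1[C@@H](C/C=C2/C(=O)OC[C@H]2OC(C)=O)[C@]2(C)CC[C@@H](OC(C)=O)[C@@](C)(CO[Si](C)(C)C(C)(C)C)[C@H]2C[C@@H]1O` gives 9790 nM
- compound 2 `C=C1[C@@H](OC(C)=O)C[C@@H]2[C@](C)(CO[Si](C)(C)C(C)(C)C)[C@H](OC(C)=O)CC[C@@]2(C)[C@@H]1C[C@@H](Nc1cccc(F)c1)C1=CCOC1=O` gives 4560 nM
- compound 3 `C=C1[C@@H](OC(C)=O)C[C@@H]2[C@](C)(COC=O)[C@H](OC(C)=O)CC[C@@]2(C)[C@@H]1C[C@@H](Nc1cccc(F)c1)C1=CCOC1=O` gives 28600 nM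

Compound 2 stands lowest of the three numbers in this assay. Compound 1 sits above it by a margin beyond the scatter, and compound 3 further above still; the single-point step a 6.3-fold higher number from compound 2 to compound 3 (0.80 log units; beyond the scatter) is the only one measured so far, and it concerns the oxygen on a saturated carbon, not the amine substituent.

Compound 4 `C=C1[C@@H](OC(C)=O)C[C@@H]2[C@](C)(CO[Si](C)(C)C(C)(C)C)[C@H](OC(C)=O)CC[C@@]2(C)[C@@H]1C[C@@H](Nc1ccc(OC)c(OC)c1)C1=CCOC1=O` differs from compound 2 by 3,4-dimethoxyphenyl in place of 3-fluorophenyl on an amine nitrogen. Going by the values given here, no measured step touches this position. The step from compound 2 to compound 3 concerns another part of the molecule and gives no reading on the aryl group of the amine. Compounds 1 and 2 differ in more than one place and offer no single-point comparison either. In the absence of any bearing step, the expectation for compound 4 in this assay is a number close to that of compound 2, with no step beyond the scatter: the change a 1.1-fold higher number from compound 2 to compound 4 (0.04 log units; within the scatter) is what is expected. Compound 4 is therefore estimated at 5000 nM, in a range from 1500 nM to 16000 nM, the width of the range reflecting the lack of any measured precedent for this change.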

Compound 4, half-maximal inhibitory concentration: 5800 nM
Compound 4: middle estimate off by 1.2-fold (0.06 log units), on the low side, within the range that was stated.
By their numbers in this assay, from the lowest: compounds 2, 4 and 1 (each within the scatter of the next, the first and the last beyond it); then compound 3.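

In this assay, the aryl group on the amine nitrogen now has a single-point reading, a 1.3-fold higher number from compound 2 to compound 4 (0.10 log units; within the scatter), which the step on the oxygen on a saturated carbon, a 6.3-fold higher number from compound 2 to compound 3 (0.80 log units; beyond the scatter), could not supply. At this position, 3,4-dimethoxyphenyl, with 10 heavy atoms and 2 hydrogen-bond acceptors, stands in for 3-fluorophenyl, with 7 heavy atoms and 0 hydrogen-bond acceptors, and the number stays within the scatter, so this change is tolerated in this assay, unlike the change at the oxygen. No measurement on hand offers an explanation for this result.

Going by these compounds, both aryl groups compared here carry one six-membered aromatic ring of carbon only, so it remains open whether a pyridine ring, a saturated cyclohexyl group, or a phenyl ring bearing a carboxylic acid would also stay within the scatter of compound 2. On these data alone, it is also open whether the same aryl change would read alike with the smaller group of compound 3 on the oxygen, as both compound 2 and compound 4 carry the silyl group there.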